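Step from compound 3 to compound 4 on the amide nitrogen

The source may report more compounds than this note shows. Statements on the series, on what has been measured and on what is new or still open speak of the compounds shown alone.

Compound 3 `Cc1cccc(-c2noc(C3CC(=O)N(c4ccc(Cl)c(Cl)c4)C3)n2)c1` gives 390 nM in an in vitro functional assay on HEK293-A cells for positive allosteric modulation of metabotropic glutamate receptor 5 (Homo sapiens), read by FLIPR and calcium flux (on this read-out lower numbers stand for an effect already at smaller amounts and higher numbers for an effect only at larger amounts of compound), the second highest of the three numbers. Compound 1 `Cc1cccc(-c2noc(C3CC(=O)N(c4ccc(C)c(Cl)c4)C3)n2)c1` gives 240 nM, and a 1.6-fold higher number from compound 1 to compound 3 (0.21 log units; within the scatter). Compound 2 `Cc1ccc(N2CC(c3nc(-c4cccc(C(F)(F)F)c4)no3)CC2=O)cc1` gives 3400 nM, beyond the scatter from compound 3. Compound 4 `Cc1ccc(N2CC(c3nc(-c4cccc(C)c4)no3)CC2=O)cc1` is unmeasured; it differs from compound 3 by 4-methylphenyl in place of 3,4-dichlorophenyl on an amide-type nitrogen in a ring. For the measured compounds named here, no measured single-place step leads to compound 4. Going by the values given here, the only single-place step, from compound 1 to compound 3, stayed within the scatter, which speaks for tolerance at that ring, whereas compound 2, which differs from compound 4 in more than one place, sits well higher. Compound 4 is therefore expected to give 900 nM (range 300 nM to 3000 nM) in this assay, a step of a 2.3-fold higher number from compound 3 to compound 4 (0.36 log units; beyond the scatter).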

Compound 4, half-maximal effective concentration: 1300 nM
Estimate against measurement, compound 4: 1.4-fold (0.16 log units) below; low and high end bracket the measured number.
By their numbers in this assay, from the lowest: compounds 1 and 3 (each within the scatter of the next); then compound 4; then compound 2.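

In this assay, the aryl group on the amide-type nitrogen now responds beyond the scatter: 4-methylphenyl in place of 3,4-dichlorophenyl gives a 3.3-fold higher number from compound 3 to compound 4 (0.52 log units; beyond the scatter), and hydrogen in place of chloro on an aromatic carbon gives a 5.4-fold higher number from compound 1 to compound 4 (0.73 log units; beyond the scatter), whereas the earlier chloro-for-methyl step stayed within the scatter. Methyl in place of trifluoromethyl on an aromatic carbon gives a 2.6-fold lower number from compound 2 to compound 4 (0.42 log units; beyond the scatter), so that second site of change also matters. Nothing available here accounts for these steps. Open, from the compounds shown here alone, is whether a nitrile, a methoxy or an amine in place of the chloro of compound 1 would keep its number.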